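Trifluoromethyl on the phenyl ring of compound 2

A few compounds are considered here, and "the series" means these few. Any claim that something is new, unique, unknown or untested is made for them only; others in the source may bear on it.

Measured so far:
compound 1 `N=C(NCCCc1c[nH]cn1)NCCSC(c1ccccc1)c1ccccn1` gives 6.6
compound 2 `N=C(NCCCc1c[nH]cn1)NCCC(c1ccccc1)c1ccccn1` gives 7.39
compound 3 `N/C(=N\CCC(c1ccc(O)cc1)c1ccccn1)NCCCc1c[nH]cn1` gives 6.63

All three numbers come from a functional assay on cardiac atrium for agonist activity at histamine H2 receptor (Cavia porcellus); on this read-out higher numbers stand for higher potency (the scale is a negative logarithm) and lower numbers for lower potency. Among them compound 2 stands highest: compound 3 lies lower by a margin beyond the usual scatter, and compound 1 lies lower by a similar margin. Compound 4 `N=C(NCCCc1c[nH]cn1)NCCC(c1cccc(C(F)(F)F)c1)c1ccccn1` has not yet been measured in this assay. It differs from compound 2 in one place: trifluoromethyl in place of hydrogen on an aromatic carbon, so that phenyl becomes 3-(trifluoromethyl)phenyl. Within the data shown here, no pair of the measured compounds shows this kind of change, so its effect has to be guessed rather than read off a neighbouring step. Among the measured compounds shown here, the measured set gives no example of a substituent on this phenyl ring that keeps the level of compound 2. For that reason a small loss is expected, a step from compound 2 to compound 4 of about a number 0.39 log units lower from compound 2 to compound 4 (beyond the scatter). Compound 4 is therefore estimated at 7, within a range from 6.3 to 7.7.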

Compound 4, negative logarithm of the half-maximal effective concentration: 7.43
Compound 4: the middle estimate sits 0.43 log units below what was measured; low and high end bracket the measured number.
By their numbers in this assay, from the lowest: compounds 1 and 3 (each within the scatter of the next); then compounds 2 and 4 (each within the scatter of the next).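

In this assay, putting trifluoromethyl on this phenyl ring gives a number 0.04 log units higher from compound 2 to compound 4 (within the scatter), so the two compounds cannot be told apart on this read-out. This shows that the aromatic carbon meta to a large group can carry a group of four heavy atoms in place of a hydrogen while the number stays at the level of compound 2, the first direct view of a single change at this place. Nothing measured here offers an explanation for why the number holds.

As far as these compounds go, what stays open is whether other groups on the same carbon, such as methoxy, an amine or a carboxylic acid, would also keep this level. Also open, from the compounds shown here alone, is whether trifluoromethyl on a different carbon of this phenyl ring would leave the number unchanged in the same way.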